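The source may report more compounds than this note shows. Statements on the series, on what has been measured and on what is new or still open speak of the compounds shown alone.

Measured compounds:
- compound 1 `Cc1cccc(/C(N)=N/NC(=S)N2CCSCC2)n1`: 7.3%
- compound 2 `Cc1cccc(/C(N)=N/NC(=S)N2CCOCC2)n1`: 11.7%
- compound 3 `Cc1cccc(/C(N)=N/NC(=S)N2CCCCC2)n1`: 19.5%

All three share one core and differ only in the saturated ring attached to the thiocarbonyl carbon. In a functional assay on MCF7 cells (Homo sapiens) for cytotoxicity, read by MTT assay, with a stated time of 72 h, tested at 1 uM (a higher number here means more inhibition of growth at the concentration tested, a lower number less inhibition of growth), compound 3 gives 19.5%, the highest of the three numbers. Its distance from compound 1 is a number 12.2 percentage points higher from compound 1 to compound 3 (beyond the scatter), but its distance from compound 2 is only a number 7.8 percentage points higher from compound 2 to compound 3 (within the scatter), and between compound 1 and compound 2 the step is a number 4.4 percentage points higher from compound 1 to compound 2 (within the scatter).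

Compound 4 `Cc1cccc(/C(N)=N/NC(=S)N2CCCC2)n1` continues this series of ring swaps: pyrrolidin-1-yl in place of piperidin-1-yl on a thiocarbonyl carbon. The steps seen so far all replace one ring on the same thiocarbonyl carbon with another; two of the three stayed within the scatter, and the largest was only modest. Nothing measured separates a five-membered ring from a six-membered one, so the swap to pyrrolidin-1-yl is taken to behave like the earlier swaps: a small shift, most likely downward from the top of the series, and not clearly beyond the scatter. The expected step from the measured number is a number 4.5 percentage points lower from compound 3 to compound 4 (within the scatter). Compound 4 is therefore estimated at 15%, with a likely range from 5% to 27% in this assay.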

Compound 4, percent growth inhibition at one concentration: 17.4%
Beside the measured number, compound 4's estimate is 2.4 percentage points below it; the range from low to high includes it.
By their numbers in this assay, from the lowest: compounds 1, 2, 4 and 3 (each within the scatter of the next, the first and the last beyond it).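

The swap from piperidin-1-yl to pyrrolidin-1-yl on the thiocarbonyl carbon gives, in this assay, a number 2.1 percentage points lower from compound 3 to compound 4 (within the scatter), so these two rings, which differ in ring size and both carry nitrogen as their only hetero atom, cannot be told apart in this read-out. The comparisons with the other two rings give a number 5.7 percentage points higher from compound 2 to compound 4 (within the scatter) and a number 10.1 percentage points higher from compound 1 to compound 4 (beyond the scatter), so pyrrolidin-1-yl repeats what piperidin-1-yl showed: each stands clear of thiomorpholin-4-yl. Compound 2, with morpholin-4-yl, goes against any clean split. It lies within the scatter of all three other compounds. No measurement shown here offers an explanation for these differences.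

Still open, on these data alone, is whether an azepan-1-yl ring, a piperazin-1-yl ring or an open-chain diethylamino group on the thiocarbonyl carbon would stay within this same narrow band of numbers or move clearly away from it. All four compounds also share one core, so the compounds shown cannot tell whether the gap separating thiomorpholin-4-yl from the two rings without a second hetero atom would hold on a different core.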